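Paw edema series: removing one pyridine methyl

This account rests on a few compounds, and the source may have more. Where it says the series, first, only, none or still open, it means among the compounds named here.

Three compounds have numbers in a functional assay on the whole organism (strain Sprague-Dawley) for inhibition, with Rattus norvegicus as the target, read by paw edema, with a stated time of 180 min, at a dose of 30 mg/kg by the oral route; on this read-out lower numbers stand for a weaker effect and higher numbers for a stronger effect at the one dose given. Compound 1 `COc1c(C)cnc(CNc2ccc3c(c2)nc(C)n3C[C@@H](O)[C@H]2O[C@H](O)[C@@H](O)[C@H]2O)c1C` gives 56%, compound 2 `Cc1nc2cc(NCc3ccccn3)ccc2n1C[C@@H](O)[C@H]1O[C@H](O)[C@@H](O)[C@H]1O` gives 52%, and compound 3 `COc1c(C)cnc(CNc2ccc3[nH]c(C)nc3c2)c1C` gives 53%. Compound 3 sits second of the three numbers, but the value of compound 2 and the value of compound 1 both lie within the scatter of it, so no order among the three is established.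

The two measured steps are small: a number 4 percentage points lower from compound 1 to compound 2 (within the scatter), which strips the methoxy and both methyls from the pyridine in one go, and a number 3 percentage points lower from compound 1 to compound 3 (within the scatter), which concerns the other end of the core.

Compound 4 `COc1ccnc(CNc2ccc3[nH]c(C)nc3c2)c1C` differs from compound 3 by hydrogen in place of methyl on an aromatic carbon. Within the data shown here, the only step that touches the pyridine substituents, from compound 1 to compound 2, removed more than this and stayed within the scatter, so no step beyond the scatter is expected here either: a number 1 percentage points lower from compound 3 to compound 4 (within the scatter) is the estimated change. Compound 4 is therefore expected to give 52%, with a range from 40% to 64%.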

Compound 4, a percentage reported as inhibition, in the whole organism at one dose (the size of the read-out at that dose, not a potency): 55%
Compound 4: middle estimate off by 3 percentage points, on the low side; low and high end bracket the measured number.
By their numbers in this assay, from the lowest: compounds 2, 3, 4 and 1 (each within the scatter of the next).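

Among these compounds, with the methyl as the only change, the step in this assay is a number 2 percentage points higher from compound 3 to compound 4 (within the scatter), so this carbon, ortho to a methoxy group, can carry hydrogen instead of methyl without a change beyond the scatter at this one dose. The earlier step on the pyridine changed the methoxy and both methyls together, so it could not speak for this position alone. No measurement on hand gives a reason for this result.

Still open, on these data alone, is whether a different group on this aromatic carbon, such as an ethyl chain, a chlorine atom or a carboxylic acid, would give a step beyond the scatter. A single dose also leaves open whether compound 3 and compound 4 would stay within the scatter of each other at other doses.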